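This account rests on a few compounds, and the source may have more. Where it says the series, first, only, none or still open, it means among the compounds named here.

The compounds here share a core in which two benzene rings are joined by a carbonyl and a double bond, and they were tested in an assay on isolated protein for inhibition of Amine oxidase [flavin-containing] B (Homo sapiens); on this read-out lower numbers stand for stronger inhibition and higher numbers for weaker inhibition. Compound 1, `CCOc1ccc(C(=O)/C=C/c2ccc(C)cc2)cc1`, gives 210 nM in this assay, the higher of the two numbers measured. Compound 2, `COc1cccc(C(=O)/C=C/c2ccc(O/N=C(\C)c3cccc4ccccc34)cc2)c1`, gives 42 nM, a lower number whose gap to compound 1 lies beyond the scatter. Compound 3, `O=C(/C=C/c1ccc(F)cc1)c1ccc(-n2ccnc2)cc1`, reaches only a limit of the assay, > 10000 nM; this is the limit of > 10000 nM in this assay, at which 1 of the 3 values shown sits, and not a number.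

Compound 4, `CCOc1ccc(C(=O)/C=C/c2ccc(O)cc2)cc1`, has not yet been measured. It differs from compound 1 in one place: hydroxy in place of methyl on an aromatic carbon. For the measured compounds named here, no step between measured compounds tells what this exchange does, so the expectation rests on compound 1 alone, whose value of 210 nM is the starting point. The step from compound 1 to compound 4 is expected to be small, at most a modest move toward a higher number, a 2.4-fold higher number from compound 1 to compound 4 (0.38 log units; beyond the scatter). Compound 4 is therefore estimated at 500 nM, with a range from 100 nM to 3000 nM.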

Compound 4, half-maximal inhibitory concentration: 210 nM
Compound 4: middle estimate off by 2.4-fold (0.38 log units), on the high side; low and high end bracket the measured number.
By their numbers in this assay, from the lowest: compound 2; then compounds 1 and 4 (each within the scatter of the next). At a limit, above all of these: compound 3.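

Putting hydroxy in place of methyl on this aromatic carbon brings no change at the digits printed from compound 1 to compound 4 (within the scatter) in this assay. For the compounds shown here, this is the first single exchange that can be read, and it shows that, for this pair, a group with one hydrogen-bond donor and one hydrogen-bond acceptor can stand where methyl, with neither, stood, and inhibition stays within the usual scatter. Nothing among the compounds shown explains why these two groups read alike.

On these data alone, whether an amine or a carboxylic acid on this same aromatic carbon would also leave the number in place remains open. It is also open what the ethoxy group contributes, since no pair shown changes that group alone.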